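Toward compound 4: a chloropyridinyl amide on the shared core

The compounds below may be only part of what the source reports. "The series", "measured", "known", "first", "only" and "open" are said of these compounds alone.

Measured so far in an ADME assay on Raji cells (Homo sapiens) for inhibition, with a stated time of 72 h; a lower number here means that less compound is needed, a higher number that more compound is needed for the effect:
Compound 1 `C=CC(=O)Nc1cccc(-c2nc3ccccc3s2)c1` gives a limit of > 25000 nM.
Compound 2 `O=C(CCl)Nc1cccc(-c2nc3ccccc3s2)c1` gives 1700 nM.
Compound 3 `CC(C)(CCl)C(=O)Nc1cccc(-c2nc3ccccc3s2)c1` gives a limit of > 25000 nM.

Compound 3 sits at the limit of > 25000 nM in this assay, at which 2 of the 3 values shown sit, and is therefore not placed among the measured values. Compound 4 `O=C(Nc1cccc(-c2nc3ccccc3s2)c1)c1ccnc(Cl)c1` differs from compound 3 by 2-chloropyridin-4-yl in place of 1-(chloromethyl)-1-methylethyl on a carbonyl carbon. Going by the values given here, the steps that bear on this change are an at least 14-fold higher number from compound 2 to compound 3 (1.16 log units; beyond the scatter) and an at least 14-fold lower number from compound 1 to compound 2 (1.16 log units; beyond the scatter); the step that the two limits leave unreadable from compound 1 to compound 3 gives no readable size. Only compound 2, with chloromethyl on the carbonyl carbon, gave a number in this assay; compound 1 and compound 3 each gave a limit. Compound 4 carries neither chloromethyl nor vinyl on the carbonyl carbon. Compound 4 is therefore estimated at 20000 nM, within 5000 nM to 25000 nM. The step from compound 3 to compound 4 is expected to be an at least 1.2-fold lower number from compound 3 to compound 4 (0.09 log units; that floor lies within the scatter), with a limit again the most likely outcome.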

Compound 4, half-maximal effective concentration: > 25000 nM
Compound 4: only a limit was reported; the forecaster's own chance of this, stated with the estimate: 60%; at least 1.2-fold (0.09 log units) between middle value and limit.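

In this assay, 2-chloropyridin-4-yl in place of chloromethyl on the carbonyl carbon gives an at least 14-fold higher number from compound 2 to compound 4 (1.16 log units; beyond the scatter) and shows that a chlorine carried on an aromatic ring does not bring back the number seen with compound 2. Compound 4 gives only a limit, > 25000 nM. Going by these compounds alone, the steps to compound 4 from compound 1 and from compound 3 cannot be read, and compound 2 remains the only compound with a number: the limit of > 25000 nM in this assay, at which 3 of the 4 values shown sit.

From the compounds shown here alone, it remains open whether a 2-chloroethyl chain or an aminomethyl group on the carbonyl carbon would give a number like that of compound 2 or another limit.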